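Shifting the Bromine on the Hydrazone Phenyl Ring

This account rests on a few compounds, and the source may have more. Where it says the series, first, only, none or still open, it means among the compounds named here.

Measured compounds:
compound 1: `CC1CC/C(=N\Nc2ccc(Cl)cc2)c2ncc(C(=O)O)c(=O)n21`, 0.5 umol/kg
compound 2: `CC1CC/C(=N\Nc2cccc(Br)c2)c2ncc(C(=O)O)c(=O)n21`, 0.4 umol/kg

In a functional assay on the whole organism for inhibition, with Rattus norvegicus as the target (on this read-out higher numbers stand for an effect only at larger amounts of compound and lower numbers for an effect already at smaller amounts), compound 1 gives 0.5 umol/kg, and compound 2 gives 0.4 umol/kg. Among these two values compound 2 carries the smaller number, yet the gap to compound 1 is within the scatter, so the two cannot be told apart. Compound 3 `CC1CC/C(=N\Nc2ccc(Br)cc2)c2ncc(C(=O)O)c(=O)n21` is not yet measured. It differs from compound 2 as follows: 4-bromophenyl in place of 3-bromophenyl on an amine nitrogen. Among the compounds with values here, the only measured step that touches the halogen on this phenyl ring is a 1.3-fold lower number from compound 1 to compound 2 (0.10 log units; within the scatter), and it stays within the scatter even though both the halogen and its place on the ring were exchanged at once. With no step beyond the scatter to build on, the change to compound 3 is expected to leave this assay essentially unchanged, that is a 1.3-fold higher number from compound 2 to compound 3 (0.10 log units; within the scatter). Compound 3 is therefore estimated at 0.5 umol/kg, with a range from 0.2 umol/kg to 1.2 umol/kg.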

Compound 3, dose for 50% inhibition: 0.8 umol/kg
For compound 3 the middle estimate is 1.6-fold (0.20 log units) below the measured one; the range from low to high includes it.
By their numbers in this assay, from the lowest: compounds 2, 1 and 3 (each within the scatter of the next).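

Read alone in this assay, moving the bromine gives a 2.0-fold higher number from compound 2 to compound 3 (0.30 log units; within the scatter) and so separates the place on the ring from the identity of the halogen, which the earlier step had changed together. With the place held at the 4-bromophenyl and 4-chlorophenyl groups, bromo in place of chloro gives a 1.6-fold higher number from compound 1 to compound 3 (0.20 log units; within the scatter) and likewise stays within the scatter. Neither single change therefore shows a real difference in this assay, and nothing available here accounts for the numbers.

The compounds shown leave open whether the 3-chlorophenyl group would fit the same narrow band, and whether an unsubstituted phenyl would do so too. They also leave open whether a methoxy group or a nitrile in place of the halogen would shift the number beyond the scatter.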